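A few compounds are considered here, and "the series" means these few. Any claim that something is new, unique, unknown or untested is made for them only; others in the source may bear on it.

Measured compounds:
Compound 1 `COc1cc(C(=O)/C=C\Nc2ccc(-c3nc4cc(OC)c(OC)c(OC)c4s3)cc2C)cc(OC)c1OC` gives 11100 nM.
Compound 2 `COc1cc(OC)c2sc(-c3ccc(N/C=C\C(=O)c4ccc(OC)c(F)c4)c(C)c3)nc2c1` gives 14700 nM.
Compound 3 `COc1ccc(C(=O)/C=C\Nc2ccc(-c3nc4cc(OC)c(OC)c(OC)c4s3)cc2)cc1[N+](=O)[O-]` gives 11400 nM.

These three values come from a functional assay on HeLa cells (Homo sapiens) for antiproliferative activity, read by sulforhodamine B assay, with a stated time of 48 h; on this read-out lower numbers stand for stronger inhibition and higher numbers for weaker inhibition. Compound 1 has the lowest of the three numbers, yet compound 3 and compound 2 both sit within the usual scatter of it, so the three measured compounds cannot be ranked against one another on these data. Across them, the ring on the carbonyl carbon changes while the shared core stays the same, and the numbers stay level.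

Compound 4 `COc1ccc(C(=O)/C=C\Nc2ccc(-c3nc4cc(OC)c(OC)c(OC)c4s3)cc2C)cc1O` has not been measured in this assay. It differs from compound 1 in one place: 3-hydroxy-4-methoxyphenyl in place of 3,4,5-trimethoxyphenyl on a carbonyl carbon. Within the data shown here, no measured pair shows this exact change, so its effect is inferred only from the measured set. Because compound 2 gives 14700 nM and compound 3 gives 11400 nM with other groups on the carbonyl carbon, the step from compound 1 to compound 4 is expected to be small, a 1.1-fold higher number from compound 1 to compound 4 (0.03 log units; within the scatter), not beyond the scatter in either direction. Compound 4 is therefore estimated at 12000 nM, with a likely range from 5000 nM to 30000 nM.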

Compound 4, half-maximal inhibitory concentration: 11400 nM
The estimate for compound 4 lay 1.1-fold (0.02 log units) above the measured number, within the range that was stated.
By their numbers in this assay, from the lowest: compounds 1, 3, 4 and 2 (each within the scatter of the next).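

In this assay, among these compounds, the exchange of 3,4,5-trimethoxyphenyl for 3-hydroxy-4-methoxyphenyl on a carbonyl carbon gives the first step at this position between compounds that differ in one place only (a 1.0-fold higher number from compound 1 to compound 4 (0.01 log units; within the scatter)), and that step lies within the scatter. The group that enters has fewer heavy atoms and carries a hydrogen-bond donor that the group leaving lacks, yet the two numbers stay level on this read-out. Nothing shown accounts for this result.

All the groups shown on this carbonyl carbon are substituted phenyl rings, so it remains open whether a pyridine ring, a cyclohexyl group or a 4-aminophenyl group there would give a number beyond the scatter of compound 1. From the compounds shown here alone, it also remains open whether the same exchange would give as small a step on another core.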